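Moving hydroxyl groups around the shared core

A few compounds are considered here, and "the series" means these few. Any claim that something is new, unique, unknown or untested is made for them only; others in the source may bear on it.

Compound 1 `Oc1cccc(-c2cc(-c3ccccc3O)nc(-c3ccccc3O)c2)c1`: 80 nM
Compound 2 `Oc1ccc(-c2cc(-c3cccc(O)c3)cc(-c3ccccc3O)n2)cc1`: a limit only

In an ADME assay on HEK293 cells (Homo sapiens) for cytotoxicity, read by CCK-8 assay, with a stated time of 4 days (a lower number here means a stronger inhibitor, a higher number a weaker inhibitor), compound 1 gives 80 nM. For compound 2 the run reached only an assay limit, > 50000 nM, as recorded in the limit of > 50000 nM in this assay, at which 1 of the 2 values shown sits. The step of an at least 620-fold higher number from compound 1 to compound 2 (2.79 log units; beyond the scatter) is therefore large. Compound 3 `Oc1ccc(-c2cc(-c3ccc(O)cc3)nc(-c3ccccc3O)c2)cc1` differs from compound 2 by 4-hydroxyphenyl in place of 3-hydroxyphenyl on an aromatic carbon. Going by the values given here, no measured step swaps 3-hydroxyphenyl for 4-hydroxyphenyl; the single measured step concerns the 2-hydroxyphenyl, which compound 3 keeps. Since compound 2 already sits at the limit, compound 3 is expected to remain there, a change of about a step that the limit leaves unreadable from compound 2 to compound 3. Compound 3 is estimated at 60000 nM, between 20000 nM and 200000 nM.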

Compound 3, half-maximal inhibitory concentration: 26300 nM
Beside the measured number, compound 3's estimate is 2.3-fold (0.36 log units) above it; measured number inside the range.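

Going by these compounds alone, this is the first change read at the position opposite the ring nitrogen; the earlier step concerned a 2-hydroxyphenyl group elsewhere on the shared core. Compound 2 stands at an assay limit, > 50000 nM. In this assay, 4-hydroxyphenyl in place of 3-hydroxyphenyl gives an at least 1.9-fold lower number from compound 2 to compound 3 (0.27 log units; that floor lies within the scatter), so this change cannot be ranked.

Open, going by these compounds, is how this position behaves with the two 2-hydroxyphenyl groups of compound 1 kept. Also open, on these data alone, is whether an amine or a methoxy group opposite the ring nitrogen would read differently from either hydroxyphenyl group.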